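Fluoro for methoxy on the pendant aryl ring

This account rests on a few compounds, and the source may have more. Where it says the series, first, only, none or still open, it means among the compounds named here.

Measured so far in a functional assay on A549 cells (Homo sapiens) for antiproliferative activity, read by MTT assay, with a stated time of 72 h; a lower number here means a stronger inhibitor, a higher number a weaker inhibitor:
compound 1 `COc1ccc(-c2ccc3ncn(-c4cc(OC)c(OC)c(OC)c4)c3c2)cc1` gives > 10000 nM there.
compound 2 `COc1cc(-n2cnc3ccc(-c4cccc([N+](=O)[O-])c4)cc32)cc(OC)c1OC` gives 5410 nM there.
compound 3 `COc1cc(-n2cnc3ccc(-c4ccc(O)cc4)cc32)cc(OC)c1OC` gives 5090 nM there.

For compound 1 the value is only a limit of this assay (the limit of > 10000 nM in this assay, at which 1 of the 3 values shown sits). Compounds 2 and 3 sit within the scatter of each other a 1.1-fold lower number from compound 2 to compound 3 (0.03 log units; within the scatter).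

Compound 4 `COc1cc(-n2cnc3ccc(-c4ccc(F)cc4)cc32)cc(OC)c1OC` differs from compound 1 by fluoro in place of methoxy on an aromatic carbon. The steps touching the same ring both gave only floors that lie within the scatter: an at least 1.8-fold lower number from compound 1 to compound 2 (0.26 log units; that floor lies within the scatter) and an at least 1.9-fold lower number from compound 1 to compound 3 (0.29 log units; that floor lies within the scatter). Each step away from compound 1 on this ring reached a measurable value, so a modest lowering in this assay is expected for compound 4, though it may again end at the limit. The estimated step is an at least 1.4-fold lower number from compound 1 to compound 4 (0.15 log units; that floor lies within the scatter). Compound 4 is therefore expected at 7000 nM, between 2500 nM and 25000 nM.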

Compound 4, half-maximal inhibitory concentration: 6740 nM
For compound 4 the middle estimate is 1.0-fold (0.02 log units) above the measured one; measured number inside the range.
By their numbers in this assay, from the lowest: compounds 3, 2 and 4 (each within the scatter of the next). At a limit, above all of these: compound 1.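

In this assay, the 4-fluorophenyl group gives a third measurable value, and the steps to the other two measurable compounds stay within the scatter (a 1.3-fold higher number from compound 3 to compound 4 (0.12 log units; within the scatter); a 1.2-fold higher number from compound 2 to compound 4 (0.10 log units; within the scatter)). Fluoro in place of methoxy gives only a floor that lies within the scatter (an at least 1.4-fold lower number from compound 1 to compound 4 (0.17 log units; that floor lies within the scatter)). The value of compound 1 is a limit, so the methoxy compound cannot be placed against the others: the limit of > 10000 nM in this assay, at which 1 of the 4 values shown sits.

As far as these compounds go, whether an amine or a carboxylic acid on this ring would move the number beyond the scatter stays open. So does the effect of any change elsewhere on the shared core.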